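The source may report more compounds than this note shows. Statements on the series, on what has been measured and on what is new or still open speak of the compounds shown alone.

Measured compounds in a functional assay on the whole organism (artery, strain albino) with Rattus norvegicus as the target, with a stated time of 60 min, at a dose of 10 mg/kg by the oral route; a lower number here means less inhibition, a higher number more inhibition at the dose given (going by the name of the read-out):

compound 1, `CC1=C(C(=O)Nc2ccc(Br)cc2)C(c2ccc(Cl)cc2Cl)N=C(SCc2ccc(F)cc2)N1`: 16.9%
compound 2, `COc1ccc(C2N=C(SCc3ccccc3Cl)NC(C)=C2C(=O)Nc2ccc(Br)cc2)cc1`: 6.7%
compound 3, `CC1=C(C(=O)Nc2ccc([N+](=O)[O-])cc2)C(c2ccc(Br)cc2)N=C(SCc2ccccc2)N1`: 8.2%

Compound 3 gives the second highest of the three numbers, yet all three lie within the usual scatter of one another, so no order among them can be read. Compound 4, `CC1=C(C(=O)Nc2ccc([N+](=O)[O-])cc2)C(c2ccc(Br)cc2)N=C(SCc2cccc(Cl)c2)N1`, has not been measured. It differs from compound 3 by a single change, (chloro in place of hydrogen on an aromatic carbon), on the benzyl that sits on the sulfur. Among the compounds with values here, no step between measured compounds with this change is available, so no size or direction beyond the scatter is expected for the move from compound 3 to compound 4. For compound 4 the expected value in this assay is 10%, between 0% and 25%, an expected step of a number 1.8 percentage points higher from compound 3 to compound 4 (within the scatter).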

Compound 4, a percentage reported as inhibition, in the whole organism at one dose (the size of the read-out at that dose, not a potency): 4.1%
Beside the measured number, compound 4's estimate is 5.9 percentage points above it; the range from low to high includes it.
By their numbers in this assay, from the lowest: compounds 4, 2, 3 and 1 (each within the scatter of the next, the first and the last beyond it).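

In this assay, within the data shown here, chloro in place of hydrogen on the benzyl on the sulfur gives a number 4.1 percentage points lower from compound 3 to compound 4 (within the scatter) and so provides the first step here that comes from a single change. At this dose, going from benzyl to 3-chlorobenzyl produces no readable effect on inhibition in either direction. No other measurement bears on this result.

On these data alone, it remains open whether chloro elsewhere on that ring would give a step beyond the scatter. The same question applies to an amine or a carboxylic acid at this place.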